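Notes on moving the methylcarbamoyl group to compound 4

A few compounds are considered here, and "the series" means these few. Any claim that something is new, unique, unknown or untested is made for them only; others in the source may bear on it.

Measured so far in an ADME assay on C8166 cells (Homo sapiens) for cytotoxicity (on this read-out lower numbers stand for higher toxicity in this test and higher numbers for lower toxicity in this test), for these compounds:
- compound 1 `CCN1C(=O)N(c2ccccc2)C(=O)N(c2ccccc2)c2cc(C(F)(F)F)ccc21` gives > 4000 nM as a limit
- compound 2 `CCN1C(=O)N(c2ccc(O)cc2)C(=O)N(c2ccccc2)c2cc(C(F)(F)F)ccc21` gives 35000 nM as a number
- compound 3 `CCN1C(=O)N(c2cccc(C(=O)NC)c2)C(=O)N(c2ccccc2)c2cc(C(F)(F)F)ccc21` gives > 22000 nM as a limit

Compound 3 stands at the limit of > 22000 nM in this assay, at which 1 of the 3 values shown sits, in this series. That is a limit and not a number, so the starting point of the step is open on its upper side.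

Compound 4 `CCN1C(=O)N(c2ccc(C(=O)NC)cc2)C(=O)N(c2ccccc2)c2cc(C(F)(F)F)ccc21` has the same atoms as compound 3, joined differently: 4-(methylcarbamoyl)phenyl in place of 3-(methylcarbamoyl)phenyl on an amide-type nitrogen in a ring and the rest of the structure stays the same.

The nearest measured steps are a step that the two limits leave unreadable from compound 1 to compound 3 and a step that the limit leaves unreadable from compound 2 to compound 3 and neither gives a size. The same holds for a step that the limit leaves unreadable from compound 1 to compound 2 in this set. Among the compounds with values here, no measured step therefore sets a size or a direction for this change, and none beyond the scatter is expected. Within the data shown here, compound 2 at 35000 nM holds the only number in this assay and it anchors the expectation of a high value.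

The estimated change is a step that the limit leaves unreadable from compound 3 to compound 4 and it stays uncertain.

For compound 4 the expected half-maximal cytotoxic concentration is 30000 nM with an estimated range from 12000 nM to 80000 nM and a limit in place of a number is also quite possible.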

Compound 4, half-maximal cytotoxic concentration: 31000 nM
The estimate for compound 4 lay 1.0-fold (0.01 log units) below the measured number, within the range that was stated.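

In this assay, within the data shown here, compound 4 gives a second plain number, so a change on this phenyl ring can be sized for the first time: the swap of 4-hydroxyphenyl for 4-(methylcarbamoyl)phenyl on the amide-type nitrogen in a ring is a 1.1-fold lower number from compound 2 to compound 4 (0.05 log units; within the scatter). Hydroxy and methylcarbamoyl therefore cannot be told apart in this test when they are compared as this pair. The steps to compound 4 from compound 3 and from compound 1 cannot be read because each starts from a limit, and the limit for compound 3 is: the limit of > 22000 nM in this assay, at which 1 of the 4 values shown sits. The limit for compound 1 is: the limit of > 4000 nM in this assay, at which 1 of the 4 values shown sits.

Still open, from the compounds shown here alone, is whether moving the methylcarbamoyl group between the 3-(methylcarbamoyl)phenyl and 4-(methylcarbamoyl)phenyl forms changes the read-out at all, since compound 3 offers no number to set against compound 4. Also open, going by these compounds, is whether a carboxylic acid or an amine on the same phenyl ring would read like compound 2 and compound 4 in this assay, or whether a longer chain in place of the ethyl group would shift the values of the series.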